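Adding a methoxy group to the aminobenzoyl hydrazone

A few compounds are considered here, and "the series" means these few. Any claim that something is new, unique, unknown or untested is made for them only; others in the source may bear on it.

Measured compounds:
compound 1 `COc1ccc(/C=N/NC(=O)c2cc([N+](=O)[O-])cc([N+](=O)[O-])c2)cc1`: 3.08
compound 2 `COc1ccc(/C=N/NC(=O)c2ccc(N)cc2)cc1`: 2.39
compound 3 `COc1ccc(/C=N/NC(=O)c2ccc([N+](=O)[O-])cc2)cc1`: 3.13

Three hydrazones sharing one core have been measured in a physicochemical assay for lipophilicity; a lower number here means a more polar compound, a higher number a more lipophilic compound. Compound 2 has the lowest number of the three: compound 1 gives 3.08 and compound 3 gives 3.13, both above it by more than the scatter. Within the data shown here, the only step between compounds that differ in one place is the exchange of amino for nitro, a number 0.74 log units higher from compound 2 to compound 3 (beyond the scatter).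

Compound 4 `COc1ccc(/C=N/NC(=O)c2ccc(N)cc2)cc1OC` is not yet measured. It differs from compound 2 by methoxy in place of hydrogen on an aromatic carbon. Among the measured compounds shown here, no measured step here concerns a methoxy group; the one measured step, nitro in place of amino, is a different exchange and does not bear on this change. The expectation for compound 4 therefore rests on the value of compound 2 alone, with no shift beyond the scatter assumed in either direction. The step that this expectation means, a number 0.01 log units higher from compound 2 to compound 4 (within the scatter), is estimated to lie within the scatter. Compound 4 is thus expected to give 2.4 in this assay, with a range from 2 to 2.8.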

Compound 4, partition coefficient: 2.14
Compound 4: middle estimate off by 0.26 log units, on the high side, within the range that was stated.
By their numbers in this assay, from the lowest: compounds 4 and 2 (each within the scatter of the next); then compounds 1 and 3 (each within the scatter of the next).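

In this assay, methoxy in place of hydrogen on an aromatic carbon, ortho to a methoxy group and meta to a large group, gives a number 0.25 log units lower from compound 2 to compound 4 (within the scatter). Among these compounds, this is the first reading at this position, as compounds 1, 2 and 3 all carry hydrogen there, and it shows that with the amino group of compound 2 kept, the added methoxy group leaves the number within the scatter of compound 2, whereas the exchange of amino for nitro gives a number 0.74 log units higher from compound 2 to compound 3 (beyond the scatter) and lies beyond it. No measurement shown offers an explanation for this result.

As far as these compounds go, it remains open whether an ethoxy group, a hydroxyl group or a chlorine atom at this position would also leave the number within the scatter of compound 2. From the compounds shown here alone, it is also open whether methoxy in place of hydrogen at this position would give a step of similar size on compound 3, which carries nitro in place of amino.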